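The compounds below may be only part of what the source reports. "The series", "measured", "known", "first", "only" and "open" are said of these compounds alone.

Compound 1 `COc1ccc(-c2cc(-c3ccc4cc(F)ccc4n3)n(-c3ccc(F)cc3)n2)cc1` and compound 2 `COc1ccc(-c2cc(-c3ccc4cc(F)ccc4n3)n(-c3ccc(OC)cc3)n2)cc1` share one core and differ only in one group on an aromatic carbon. In an ADME assay on Huh-7 cells (Homo sapiens) for inhibition, read by XTT assay, with a stated time of 3 days (a higher number here means that more compound is tolerated, a lower number that less compound is tolerated), compound 1 gives > 200000 nM, which is a limit of the assay rather than a number. In this assay compound 2 gives > 200000 nM, again a limit and not a number. For the measured compounds named here, the single step between them, a step that the two limits leave unreadable from compound 1 to compound 2, cannot be sized because both values sit at the limit of > 200000 nM in this assay, at which 2 of the 2 values shown sit. Going by the values given here, compound 2 thus stands only at a limit in this assay, and the one further value shown is a limit as well.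

Compound 3 `COc1ccc(-c2cc(-c3ccc4cc(F)ccc4n3)n(-c3ccc(S(N)(=O)=O)cc3)n2)cc1` differs from compound 2 by sulfamoyl in place of methoxy on an aromatic carbon. Among the compounds with values here, no measured step involves a sulfamoyl group, and the only step available, from compound 1 to compound 2, is unreadable, so the expectation rests on the two limits alone. For compound 3 the expected step that the limit leaves unreadable from compound 2 to compound 3 is none beyond the scatter. Compound 3 is therefore estimated at 250000 nM, with a range from 120000 nM to 600000 nM, and is expected most often to be reported once more only as a limit.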

Compound 3, half-maximal cytotoxic concentration: > 200000 nM
Compound 3 was reported as a limit (the forecaster's own chance of this, stated with the estimate: 75%); the middle value is on the limit's open side.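

No step can be read among compound 1, compound 2 and compound 3, because each value is a limit rather than a number, and all three sit at the same one in this assay: the limit of > 200000 nM in this assay, at which 3 of the 3 values shown sit.

The compounds shown leave open whether fluoro, methoxy and sulfamoyl differ at all in half-maximal cytotoxic concentration in this assay.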